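Dithiolane-coumarin triazole series: cytotoxicity working notes

A few compounds are considered here, and "the series" means these few. Any claim that something is new, unique, unknown or untested is made for them only; others in the source may bear on it.

Measured compounds:
compound 1 `CC(=O)c1cc2ccc(OCCCn3cc(CNC(=O)CCCCC4CCSS4)nn3)cc2oc1=O` — 34.6%
compound 2 `CCOC(=O)c1cc2ccc(OCCCn3cc(CNC(=O)CCCCC4CCSS4)nn3)cc2oc1=O` — 28%
compound 3 `CC(=O)c1cc2ccc(OCCCCCn3cc(CNC(=O)CCCCC4CCSS4)nn3)cc2oc1=O` — 28.9%

All three were tested in a functional assay on PC-12 cells (Rattus norvegicus) for cytotoxicity, read by MTT assay, with stated times of 3 h and 2 h, tested at 0.1 uM; on this read-out higher numbers stand for a stronger effect at the one concentration tested and lower numbers for a weaker effect. Compound 1 gives 34.6% and compound 2 gives 28%; the change between them is ethoxy in place of methyl on a carbonyl carbon, and the step of a number 6.6 percentage points lower from compound 1 to compound 2 (within the scatter) stays within the scatter. Compound 3 gives 28.9%; the difference between the core of compound 1 and the core of compound 3 is not broken down here, and the two values lie within the scatter of each other.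

Compound 4 `CCOC(=O)c1cc2ccc(OCCCCCn3cc(CNC(=O)CCCCC4CCSS4)nn3)cc2oc1=O` is not yet measured. It differs from compound 3 by ethoxy in place of methyl on a carbonyl carbon, the same change as from compound 1 to compound 2, at the same place. A step of similar size is expected, a number 5.9 percentage points lower from compound 3 to compound 4 (within the scatter), because the measured step of a number 6.6 percentage points lower from compound 1 to compound 2 (within the scatter) was small. Compound 4 is therefore estimated at 23%, between 13% and 33%.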

Compound 4, a percentage reported as activity, at one concentration (the size of the read-out at that concentration, not a potency): 34.4%
For compound 4 the middle estimate is 11.4 percentage points below the measured one; the measured number lies above the stated range.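

In this assay, ethoxy in place of methyl on a carbonyl carbon gives a number 5.5 percentage points higher from compound 3 to compound 4 (within the scatter), and the comparison with the earlier step reads: the same change on two cores in this assay, a number 6.6 percentage points lower (within the scatter) from compound 1 to compound 2 and a number 5.5 percentage points higher (within the scatter) from compound 3 to compound 4, 12.1 percentage points apart, within the scatter of two such steps. Neither the two steps nor the gap between them exceed the scatter, so these data give no sign that the change behaves differently on the two cores. They also do not show that it carries over as a real effect, since neither step is resolved from the scatter and an opposite direction on the two cores cannot be read as meaningful.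

The compounds shown leave open how a carboxylic acid or an amide would read on that carbonyl carbon, and how a longer chain in place of ethoxy would read. As far as these compounds go, whether any step between these compounds would emerge at other concentrations also remains open.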